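The source may report more compounds than this note shows. Statements on the series, on what has been measured and on what is new or still open speak of the compounds shown alone.

Measured in a functional assay on PC-3 cells (Homo sapiens) for antiproliferative activity, read by MTT assay, with a stated time of 48 h; a higher number here means a weaker inhibitor, a lower number a stronger inhibitor:
- compound 1 `CCN(CC)CCNC(=O)c1ccc(C(CC)(CC)c2ccc(OCCC(O)(CC)CC)c(C)c2)n1CC`: 3350 nM
- compound 2 `CCn1c(C(=O)N(CCC#N)CCC#N)ccc1C(CC)(CC)c1ccc(OCCC(O)(CC)CC)c(C)c1`: > 50000 nM (a limit, not a number)

For the measured compounds named here, compound 1 holds the only true number so far. The other reading is the limit of > 50000 nM in this assay, at which 1 of the 2 values shown sits.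

Compound 3 `C#CC(C)OC(=O)c1ccc(C(CC)(CC)c2ccc(OCCC(O)(CC)CC)c(C)c2)n1CC` differs from compound 1 by (1-methylprop-2-yn-1-yl)oxy in place of (2-(diethylamino)ethyl)amino on a carbonyl carbon. Going by the values given here, one measured step bears on this, since the same (2-(diethylamino)ethyl)amino group left the same carbonyl carbon there: an at least 14-fold higher number from compound 1 to compound 2 (1.17 log units; beyond the scatter). Based on that single step, with a different entering group, a higher number in this assay is expected, though with less certainty about its size. The expected move is a 3.6-fold higher number from compound 1 to compound 3 (0.55 log units; beyond the scatter). For compound 3 the estimate is 12000 nM, with an expected range of 3000 nM to 50000 nM.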

Compound 3, half-maximal inhibitory concentration: 14800 nM
The estimate for compound 3 lay 1.2-fold (0.09 log units) below the measured number; the measured number falls inside the stated range.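

At the carbonyl carbon, (1-methylprop-2-yn-1-yl)oxy in place of (2-(diethylamino)ethyl)amino still gives a measurable reading in this assay, though a weaker one: a 4.4-fold higher number from compound 1 to compound 3 (0.65 log units; beyond the scatter). Against the group on compound 2, the same entering group gives an at least 3.3-fold lower number from compound 2 to compound 3 (0.52 log units; beyond the scatter), so the groups at this place do not all fall off equally. The reading for compound 2 is a limit, not a number: the limit of > 50000 nM in this assay, at which 1 of the 3 values shown sits.

Open, on these data alone, is whether a primary amine, a carboxylic acid or a longer chain on this carbonyl carbon would match compound 1. Also open, as far as these compounds go, is whether the triple bond in compound 3 contributes to its reading.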